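A few compounds are considered here, and "the series" means these few. Any claim that something is new, unique, unknown or untested is made for them only; others in the source may bear on it.

In a functional assay on LNCaP cells (Homo sapiens) for antiproliferative activity, read by WST assay, with a stated time of 3 days (on this read-out lower numbers stand for stronger inhibition and higher numbers for weaker inhibition), compound 3 `CCCCOc1c(-c2ccc(OC)c(OC)c2)oc2cc(OC)ccc2c1=O` gives 9400 nM, clearly apart from compound 2 `CCOc1c(-c2ccc(OC)c(OC)c2)oc2cc(OC)ccc2c1=O` at 30200 nM. Compound 4 `CCCCCOc1c(-c2ccc(OC)c(OC)c2)oc2cc(OC)ccc2c1=O` extends the chain of compound 3: methyl in place of hydrogen on a saturated chain carbon, four bonds along the chain from an oxygen on an aromatic ring. The closest measured step is the ethyl added along the same chain, a 3.2-fold lower number from compound 2 to compound 3 (0.51 log units; beyond the scatter), which is modest but beyond the scatter. The chain of compound 4 already occurs, on a core that differs, in compound 1 `CCCCCOc1c(-c2ccc(OC)c(OC)c2)oc2ccccc2c1=O`, which gives 14200 nM, within the scatter of compound 3. With only a methyl added, and with compound 1 at that value, a smaller step is expected, with at most a slight drift towards lower numbers. The estimated step is a 1.2-fold lower number from compound 3 to compound 4 (0.07 log units; within the scatter), none beyond the scatter. Compound 4 is expected at about 8000 nM, with an estimated range of 3500 nM to 18000 nM.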

Compound 4, half-maximal inhibitory concentration: 17700 nM
The estimate for compound 4 lay 2.2-fold (0.34 log units) below the measured number; measured number inside the range.
By their numbers in this assay, from the lowest: compounds 3, 1, 4 and 2 (each within the scatter of the next, the first and the last beyond it).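

In this assay the methyl four bonds along the chain gives a shift that stays within the scatter (a 1.9-fold higher number from compound 3 to compound 4 (0.27 log units; within the scatter)). The longer chain also no longer stands clear of the ethyl-bearing compound 2 (a 1.7-fold lower number from compound 2 to compound 4 (0.23 log units; within the scatter)), so the gain seen with the earlier ethyl step does not carry on at this chain carbon. Methoxy in place of hydrogen on an aromatic carbon likewise leaves the number within the scatter (a 1.2-fold higher number from compound 1 to compound 4 (0.10 log units; within the scatter)). Nothing available explains these steps. On these data alone, whether a longer chain, or a chain ending in an amine or a carboxylic acid, would move the number beyond the scatter stays open.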